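The source may report more compounds than this note shows. Statements on the series, on what has been measured and on what is new or still open speak of the compounds shown alone.

Measured compounds:
Compound 1, `CCOC(=O)Cc1n[nH]c(NC(=O)c2ccc(Br)cc2)n1`: 40.4%
Compound 2, `CCOC(=O)Cc1n[nH]c(NC(=O)c2ccc(OC)cc2)n1`: 38.2%

Both compounds were tested in a functional assay on the whole organism (strain albino) for inhibition, with Rattus norvegicus as the target, read by paw edema, with stated times of 30 min and 2 h, at a dose of 5 mg/kg by the oral route; on this read-out higher numbers stand for more inhibition at the one dose given (going by the name of the read-out) and lower numbers for less inhibition. Compound 1 gives 40.4% there, and compound 2 gives 38.2%. Compound 2 therefore stands with the smaller of the two numbers shown, but its nearest neighbour is compound 1 and the gap between them is within the scatter, so the two cannot be told apart on these data.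

The next compound, compound 3, `CCOC(=O)Cc1n[nH]c(NC(=O)c2ccc([N+](=O)[O-])cc2)n1`, has not yet been measured in this assay. It differs from compound 2 in one place: nitro in place of methoxy on an aromatic carbon

Among the measured compounds shown here, only one measured step bears on this change, the exchange of one group for another on the same aromatic carbon between compound 1 and compound 2, which gave a number 2.2 percentage points lower from compound 1 to compound 2 (within the scatter). That step was within the scatter, and nothing in the two numbers suggests that this carbon is a sensitive spot. The expectation for compound 3 is therefore a step of a number 0.8 percentage points higher from compound 2 to compound 3 (within the scatter), nothing beyond the scatter. Compound 3 is estimated at 39%, with a range from 26% to 52%.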

Compound 3, a percentage reported as inhibition, in the whole organism at one dose (the size of the read-out at that dose, not a potency): 42.1%
Beside the measured number, compound 3's estimate is 3.1 percentage points below it; measured number inside the range.
By their numbers in this assay, from the lowest: compounds 2, 1 and 3 (each within the scatter of the next).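

In this assay, nitro in place of methoxy gave a number 3.9 percentage points higher from compound 2 to compound 3 (within the scatter), and nitro in place of bromo gave a number 1.7 percentage points higher from compound 1 to compound 3 (within the scatter). The aromatic carbon para to a large group has now carried three different groups, and no step among them leaves the scatter, even though the exchange of methoxy for nitro goes from 2 heavy atoms to 3, from 1 hydrogen-bond acceptor to 2, and brings in a double bond outside aromatic rings, so this position shows no sensitivity among these three compounds at this one dose. No supporting measurement is available to interpret this result.

Going by these compounds, whether an amine or a carboxylic acid on this same carbon would separate from these three groups in this assay remains open, as does the effect of a longer chain in place of the ethyl ester on the shared core. The numbers also give the size of the inhibition at one dose only, so they leave open how these compounds would compare as the dose changes.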